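The compounds below may be only part of what the source reports. "The series", "measured", "known", "first", "only" and "open" are said of these compounds alone.

Working notes. The series is read in a functional assay on MDA-MB-231 cells (Homo sapiens), read by microscopy and transwell migration, with a stated time of 24 h; on this read-out lower numbers stand for stronger inhibition and higher numbers for weaker inhibition. Compound 1 `COc1ccc(C(=O)Nc2nc(-c3cc(OC)c(OC)c(OC)c3)cs2)cc1` reaches only the limit of this assay, > 25000 nM. Compound 2 `COc1ccc(C(=O)Nc2nc(-c3cc(OC)c(OC)c(OC)c3)cs2)cc1OC` likewise gives only a limit, > 25000 nM. Compound 3 `COc1ccc(C(=O)N(C)c2nc(-c3cc(OC)c(OC)c(OC)c3)cs2)cc1OC` also sits at a limit, > 25000 nM. Accordingly a step that the two limits leave unreadable from compound 1 to compound 2 and a step that the two limits leave unreadable from compound 2 to compound 3 cannot be sized, since all three values share (the limit of > 25000 nM in this assay, at which 3 of the 3 values shown sit). The change from compound 1 to compound 2, (methoxy in place of hydrogen on an aromatic carbon), is the same kind of change as that from compound 3 to compound 4 `COc1cc(C(=O)N(C)c2nc(-c3cc(OC)c(OC)c(OC)c3)cs2)cc(OC)c1OC`, namely (methoxy in place of hydrogen on an aromatic carbon); around the place in compound 4 the carbon is in addition meta to a methoxy group. How the cores of compound 3 and compound 1 differ is not broken down here. Because every measured value rests at the limit of > 25000 nM in this assay, at which 3 of the 3 values shown sit, the step that the limit leaves unreadable from compound 3 to compound 4 is expected to remain unreadable as well. Compound 4 is estimated at 30000 nM, with a range from 15000 nM to 60000 nM.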

Compound 4, half-maximal inhibitory concentration: 470 nM
Beside the measured number, compound 4's estimate is 64-fold (1.81 log units) above it, and the stated range ends above it.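

In this assay, methoxy in place of hydrogen on an aromatic carbon gives an at least 53-fold lower number from compound 3 to compound 4 (1.72 log units; beyond the scatter), so on the core of compound 3 this change carries a large effect, beyond the scatter. The same kind of change from compound 1 to compound 2 cannot be read, nor can the step from compound 2 to compound 3, since those values rest at one limit: the limit of > 25000 nM in this assay, at which 3 of the 4 values shown sit. Only one of the two methoxy steps therefore has a size, which shows neither that the change carries over between these cores nor that it fails to.

Still open, as far as these compounds go, is whether the large step depends on the methyl on the amide-type nitrogen. Also open, from the compounds shown here alone, is whether an amine or a longer chain such as ethoxy at the same place would give a comparable number.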